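Fluorine on the Shared Core: Expected Clearance of Compound 4

The source may report more compounds than this note shows. Statements on the series, on what has been measured and on what is new or still open speak of the compounds shown alone.

Compound 3 `CC(=O)N[C@@H]1CCC[C@H](C(=O)Nc2cc(-c3cnn4c3CC(C)(C)CC4)ccn2)C1` is the only one of the three measured compounds with a number in an ADME assay on cells (Hepatocyte, Homo sapiens) for metabolic stability, using equilibrium dialysis; on this read-out lower numbers stand for slow clearance and higher numbers for fast clearance: compound 3 gives 4.3 uL/min. Compound 1 `CC(=O)N[C@@H]1CCC[C@H](C(=O)Nc2cc(-c3cnn4c3CCCC4)c(Cl)cn2)C1` reaches only the limit of < 1.2 uL/min in this assay. Compound 2 `CC(=O)N[C@@H]1CCC[C@H](C(=O)Nc2cc(-c3cnn(C)c3C)c(Cl)cn2)C1` likewise stops at the limit of < 1 uL/min. Among the measured compounds shown here, the single measured step, a step that the two limits leave unreadable from compound 1 to compound 2, has no readable size because the limit of < 1 uL/min in this assay, at which 1 of the 3 values shown sits, and the limit of < 1.2 uL/min in this assay, at which 1 of the 3 values shown sits, hide both of its ends.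

Compound 4 `CC(=O)N[C@@H]1CCC[C@H](C(=O)Nc2cc(-c3cnn4c3CC(C)(C)CC4)c(F)cn2)C1` differs from compound 3 by fluoro in place of hydrogen on an aromatic carbon. For the measured compounds named here, no measured step covers that change, so no shift beyond the usual scatter is expected. The estimate for compound 4 is 3.5 uL/min, within 1.2 uL/min to 9 uL/min. This corresponds to an expected step of a 1.2-fold lower number from compound 3 to compound 4 (0.09 log units; within the scatter).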

Compound 4, intrinsic clearance in a liver preparation (reported as CLH), per the amount of preparation that the assay uses in the Hepatocyte assay: 23 uL/min
Beside the measured number, compound 4's estimate is 6.6-fold (0.82 log units) below it; measured number above the stated range.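

Among the compounds shown here, in the Hepatocyte assay, fluoro in place of hydrogen on this aromatic carbon gives a 5.3-fold higher number from compound 3 to compound 4 (0.73 log units; beyond the scatter); the one earlier step cannot be read, so this is the first readable size for a change on the shared core. It shows that a single added atom at this position can move clearance beyond the scatter. In a physicochemical assay for solubility, in phosphate buffer, at pH 7.4 (on this read-out lower numbers stand for lower solubility and higher numbers for higher solubility), compound 3 gives 640000 nM and compound 4 gives 160000 nM, so the two read-outs shift together with this one change.

On these data alone, whether a nitrile or an amine at this position would shift either number, and in which direction, stays open. A single pair also cannot show whether the step would be the same size on another core.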